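This account rests on a few compounds, and the source may have more. Where it says the series, first, only, none or still open, it means among the compounds named here.

Measured compounds:
Compound 1, `O=C(N/N=C/c1ccc(O)c(O)c1)c1ccc(-c2nc3ccccc3s2)cc1`, gives 15100 nM in an assay on isolated protein for inhibition of Maltase-glucoamylase (Homo sapiens), with a stated time of 15 min; on this read-out higher numbers stand for weaker inhibition and lower numbers for stronger inhibition.
Compound 2, `COc1cccc(/C=N/NC(=O)c2ccc(-c3nc4ccccc4s3)cc2)c1`, gives 11100 nM in this assay.

These two numbers differ only within the scatter, so compound 2 stands level with compound 1 rather than apart from it. Compound 3, `O=C(N/N=C/c1cc(O)ccc1O)c1ccc(-c2nc3ccccc3s2)cc1`, differs from compound 2 by one change: 2,5-dihydroxyphenyl in place of 3-methoxyphenyl on a carbon with a double bond to nitrogen. Among the measured compounds shown here, the only step measured so far, a 1.4-fold lower number from compound 1 to compound 2 (0.13 log units; within the scatter), also exchanged the group on the carbon with a double bond to nitrogen and stayed within the scatter. The step of a 1.2-fold higher number from compound 2 to compound 3 (0.07 log units; within the scatter) is therefore expected to stay within the scatter, in neither direction. Compound 3 is estimated at 13000 nM, with a range from 5000 nM to 35000 nM.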

Compound 3, half-maximal inhibitory concentration: 11900 nM
Beside the measured number, compound 3's estimate is 1.1-fold (0.04 log units) above it, and the stated range covers the measured number.
By their numbers in this assay, from the lowest: compounds 2, 3 and 1 (each within the scatter of the next).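

Putting 2,5-dihydroxyphenyl in place of 3-methoxyphenyl gives a 1.1-fold higher number from compound 2 to compound 3 (0.03 log units; within the scatter) in this assay, and putting it in place of 3,4-dihydroxyphenyl gives a 1.3-fold lower number from compound 1 to compound 3 (0.10 log units; within the scatter) in the same assay. On this carbon with a double bond to nitrogen, going from 0 hydrogen-bond donors to 2 hydrogen-bond donors in the group therefore leaves the number within the scatter. Nothing available explains why these groups read level. Still open, going by these compounds, is whether a phenyl carrying an amine or a carboxylic acid, or a longer chain in place of the ring, would move the number beyond the scatter.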